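The compounds below may be only part of what the source reports. "The series", "measured", "known", "first", "only" and "open" are said of these compounds alone.

In a functional assay on brain (Rattus norvegicus, strain Wistar) for inhibition (a higher number here means a weaker inhibitor, a lower number a stronger inhibitor), compound 1 (`CCCc1ccc(-c2c(C)[nH]c(=O)n2C2CCCCC2)cc1`) gives 13900 nM and compound 2 (`CCCCCOc1ccc(-c2c(C)[nH]c(=O)n2C2CCCCC2)cc1`) gives 9100 nM. Among the measured compounds shown here, these are the only two values so far, and they lie within the scatter of each other, so compound 2 cannot be separated from compound 1. Compound 3 (`CCCCCCc1ccc(-c2c(C)[nH]c(=O)n2C2CCCCC2)cc1`) carries hexyl in place of pentyloxy on an aromatic carbon, para to a large group: hexyl in place of pentyloxy on an aromatic carbon. For the measured compounds named here, one measured step bears on this change, which is a 1.5-fold lower number from compound 1 to compound 2 (0.18 log units; within the scatter), with pentyloxy in place of propyl on an aromatic carbon. That single step offers no sign that swapping these chains moves the number in this assay, so no step beyond the scatter is expected, in either direction. The estimate amounts to an expected 1.0-fold higher number from compound 2 to compound 3 (0.02 log units; within the scatter). Compound 3 is expected at 9500 nM, with an estimated range of 4500 nM to 20000 nM.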

Compound 3, half-maximal inhibitory concentration: 13700 nM
Compound 3: middle estimate off by 1.4-fold (0.16 log units), on the low side; the range from low to high includes it.
By their numbers in this assay, from the lowest: compounds 2, 3 and 1 (each within the scatter of the next).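

In this assay, hexyl in place of pentyloxy gives a 1.5-fold higher number from compound 2 to compound 3 (0.18 log units; within the scatter). The oxygen and the one hydrogen-bond acceptor of pentyloxy can therefore be exchanged for a carbon without a change that stands out from the scatter. Extending the chain gives a 1.0-fold lower number from compound 1 to compound 3 (0.01 log units; within the scatter), so propyl, pentyloxy and hexyl on this aromatic carbon, para to a large group, cannot be told apart, and neither chain length nor the oxygen shows an effect across these three compounds. Nothing measured here offers an explanation for this flat result.

As far as these compounds go, whether any group at this place can move the number beyond the scatter remains open. A longer chain such as decyl, or a chain ending in an amine or a carboxylic acid, could test this.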